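Replacing a Chain by a Methoxyphenyl Ring: Expected Inhibition

A few compounds are considered here, and "the series" means these few. Any claim that something is new, unique, unknown or untested is made for them only; others in the source may bear on it.

Compound 1 `C=C1CC[C@@H]2[C@](C)(COC(=O)c3cccnc3)[C@H](OC(=O)c3cccnc3)CC[C@@]2(C)[C@@H]1/C=C/C1=C/C(=C\C(C)=C\CCC/C=C/C)OC1=O`: 68.9%
Compound 2 `C=C1CC[C@@H]2[C@](C)(COC(=O)c3cccnc3)[C@H](OC(=O)c3cccnc3)CC[C@@]2(C)[C@@H]1/C=C/C1=C/C(=C/c2ccco2)OC1=O`: 95.9%

In an assay on isolated protein for inhibition of Maltase-glucoamylase (Homo sapiens), tested at 100 uM (on this read-out higher numbers stand for more inhibition at the one concentration tested (going by the name of the read-out) and lower numbers for less inhibition), compound 1 gives 68.9%, the lower of the two measured numbers. Compound 2 gives 95.9%, a gap beyond the usual scatter. Compound 3 `C=C1CC[C@@H]2[C@](C)(COC(=O)c3cccnc3)[C@H](OC(=O)c3cccnc3)CC[C@@]2(C)[C@@H]1/C=C/C1=C/C(=C\c2ccc(OC)cc2)OC1=O` is not yet measured. It differs from compound 1 by a group of 8 heavy atoms (7 carbon, 1 oxygen; one six-membered aromatic ring of carbon only) in place of a group of 9 heavy atoms (9 carbon; no ring), on a double-bonded chain carbon bound to a double-bonded ring carbon. Within the data shown here, no measured pair shows this exact change, yet compound 2, which also carries a ring in place of the chain, gives 95.9%, so a rise is expected, with the step of a number 19.1 percentage points higher from compound 1 to compound 3 (beyond the scatter). Compound 3 is therefore expected to reach 88%, likely between 70% and 99%.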

Compound 3, a percentage reported as inhibition, at one concentration (the size of the read-out at that concentration, not a potency): 100%
The estimate for compound 3 lay 12 percentage points below the measured number; the whole stated range lies below it.
By their numbers in this assay, from the lowest: compound 1; then compounds 2 and 3 (each within the scatter of the next).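

At the double-bonded chain carbon bound to a double-bonded ring carbon, putting 4-methoxyphenyl in place of the chain of 9 heavy atoms gives, in this assay, a number 31.1 percentage points higher from compound 1 to compound 3 (beyond the scatter), the first direct measure of this exact change. Compound 3 reaches 100%, the top of a percentage scale, so a single concentration cannot show whether its inhibition has more room to grow. Nothing measured here explains the rise. As far as these compounds go, what the methoxy group itself contributes stays open. A plain phenyl ring or a 4-aminophenyl ring at this place would show whether inhibition stays as high.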